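The compounds below may be only part of what the source reports. "The series", "measured", "known", "first", "only" and "open" are said of these compounds alone.

Compound 1 `CN(C)C1(Cc2ccccc2)CCN(c2cc(C(F)(F)F)ccc2CNC(=O)Nc2cccc3c2CC(O)CC3)CC1` is the anchor of the pair measured so far. In an assay on CHO cells for displacement of a labelled ligand from transient receptor potential cation channel subfamily V member 1 (Homo sapiens), read by scintillation counting, with a stated time of 60 min (on this read-out higher numbers stand for weaker inhibition and lower numbers for stronger inhibition), compound 1 gives 0.95 nM, the lowest of the two numbers, with compound 2 as its nearest neighbour at a much higher value. Compound 2 `CN(C)C1(Cc2ccccc2)CCN(c2cc(C(F)(F)F)ccc2CNC(=O)Nc2cccc3c(=O)[nH]ccc23)CC1` in this assay gives 111 nM. For the measured compounds named here, the step of a 120-fold higher number from compound 1 to compound 2 (2.07 log units; beyond the scatter) is the only measured step in the set and it is large.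

Compound 3 `CN(C)C1(Cc2ccccc2)CCN(c2cc(C(F)(F)F)ccc2CNC(=O)Nc2cccc3ncccc23)CC1` is not yet measured. Relative to compound 1 the change is quinolin-5-yl in place of 3-hydroxy-1,2,3,4-tetrahydronaphthalen-5-yl on an amide-type nitrogen. As in compound 2, the 3-hydroxy-1,2,3,4-tetrahydronaphthalen-5-yl group gives way to two aromatic rings, one six-membered aromatic ring with 1 hetero atom, and the hydrogen-bond donor is lost; unlike compound 2 there is no carbonyl. Going by the values given here, the step of a 120-fold higher number from compound 1 to compound 2 (2.07 log units; beyond the scatter) is the only guide and points to a weakening. A weakening is therefore expected, a 32-fold higher number from compound 1 to compound 3 (1.50 log units; beyond the scatter), probably smaller than that seen for compound 2. Compound 3 is estimated at 30 nM in this assay, with a range of 5 nM to 200 nM.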

Compound 3, inhibition constant: 10.8 nM
Estimate against measurement, compound 3: 2.8-fold (0.44 log units) above, and the stated range covers the measured number.
By their numbers in this assay, from the lowest: compound 1; then compound 3; then compound 2.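

Aromatic quinolin-5-yl on the amide-type nitrogen does not match 3-hydroxy-1,2,3,4-tetrahydronaphthalen-5-yl in this assay, with an 11-fold higher number from compound 1 to compound 3 (1.06 log units; beyond the scatter) as the cost of the exchange. The further step, a 10-fold lower number from compound 2 to compound 3 (1.01 log units; beyond the scatter), comes with the absence of the carbonyl, so the weak number of compound 2 does not follow from two aromatic rings alone and the carbonyl-bearing ring fares worse than quinolin-5-yl here. No measurement at hand gives a reason for either step.

The compounds shown do not separate the contribution of the hydroxyl in compound 1 from that of its non-aromatic ring. As far as these compounds go, what a plain 1,2,3,4-tetrahydronaphthalen-5-yl group, or an amine in place of the hydroxyl, would give at this position remains open.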